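Shifting the methylpyridyl attachment point in a fluorophenyl tetrazole series

The source may hold more compounds than are shown below. What is called first, only, known or untested is meant among the compounds shown, and "the series" means these compounds.

Compound 1, `Fc1cc(-c2ccccn2)cc(-n2nnc(-c3ccccn3)n2)c1`: 95 nM
Compound 2, `Cc1cnccc1-c1cc(F)cc(-n2nnc(-c3ccccn3)n2)c1`: 33 nM

Going by the values given here, in an assay for binding affinity to metabotropic glutamate receptor 5 (Rattus norvegicus) (on this read-out lower numbers stand for stronger inhibition and higher numbers for weaker inhibition), compound 2 holds the lower of the two numbers; the only step measured is a 2.9-fold lower number from compound 1 to compound 2 (0.46 log units; beyond the scatter). Compound 3, `Cc1ncccc1-c1cc(F)cc(-n2nnc(-c3ccccn3)n2)c1`, differs from compound 2 in one place: 2-methylpyridin-3-yl in place of 3-methylpyridin-4-yl on an aromatic carbon. Among the compounds with values here, no measured step exchanges one methylpyridyl for another, so the step from compound 1 to compound 2 bears only loosely, showing that changing the pyridyl can move the number modestly. A shift of similar size or smaller, more likely toward a higher number, is expected: a 1.8-fold higher number from compound 2 to compound 3 (0.26 log units; within the scatter). Compound 3 is therefore estimated at 60 nM, within 20 nM to 200 nM.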

Compound 3, inhibition constant: 45 nM
Compound 3: the middle estimate sits 1.3-fold (0.12 log units) above what was measured, within the range that was stated.
By their numbers in this assay, from the lowest: compounds 2 and 3 (each within the scatter of the next); then compound 1.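

In this assay the exchange of attachment gives a 1.4-fold higher number from compound 2 to compound 3 (0.13 log units; within the scatter), so these two methylpyridyl groups cannot be told apart on this aromatic carbon. The step of a 2.1-fold lower number from compound 1 to compound 3 (0.32 log units; beyond the scatter) shows that 3-methylpyridin-4-yl is not the only methylpyridyl that stands apart from pyridin-2-yl. Nothing available explains these numbers.

Still open, going by these compounds, is what a methoxy group or an amine in place of the methyl on the pyridine would do. Also open, on these data alone, is how a plain phenyl ring would compare at this position.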